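The source may report more compounds than this note shows. Statements on the series, on what has been measured and on what is new or still open speak of the compounds shown alone.

Of the compounds shown here, two of a shared core have been measured in a functional assay on SK-MEL-2 cells (Homo sapiens) for cytotoxicity, read by sulforhodamine B assay; a higher number here means a weaker inhibitor, a lower number a stronger inhibitor. Compound 1 `COC(=O)CNc1nc(-c2ccccc2)nc2ccccc12` carries a (methoxycarbonyl)methyl group on a nitrogen on an aromatic ring, and in this assay compound 1 gives 37.6 ug/mL. Among the measured compounds shown here, compound 2 `c1ccc(-c2nc(NC3CCCCC3)c3ccccc3n2)cc1` carries a cyclohexyl group in that place, and in this assay compound 2 gives 9.63 ug/mL, the lowest of the two numbers; the only step measured so far is a 3.9-fold lower number from compound 1 to compound 2 (0.59 log units; beyond the scatter).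

Compound 3 `CNc1nc(-c2ccccc2)nc2ccccc12` differs from compound 2 in one place: methyl in place of cyclohexyl on a nitrogen on an aromatic ring. For the measured compounds named here, the one measured step bears on this only indirectly, since it shows that a cyclohexyl group in this place went together with a lower number than a small one-carbon-chain substituent, and methyl is again a small group with no ring. On that ground the number for compound 3 in this assay is expected to rise, by an estimated 2.6-fold higher number from compound 2 to compound 3 (0.41 log units; beyond the scatter), though not necessarily back to the number of compound 1. The estimate for compound 3 in this assay is therefore 25 ug/mL, with a range from 10 ug/mL to 60 ug/mL.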

Compound 3, half-maximal inhibitory concentration: 24.4 ug/mL
Beside the measured number, compound 3's estimate is 1.0-fold (0.01 log units) above it; measured number inside the range.
By their numbers in this assay, from the lowest: compound 2; then compounds 3 and 1 (each within the scatter of the next).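

In this assay, the step of a 2.5-fold higher number from compound 2 to compound 3 (0.40 log units; beyond the scatter) shows that the lower number of compound 2 holds against a plain methyl group on this nitrogen on an aromatic ring, and not only against the (methoxycarbonyl)methyl group of compound 1. The second step, a 1.5-fold lower number from compound 1 to compound 3 (0.19 log units; within the scatter), shows that taking the methoxycarbonyl off the saturated chain carbon leaves no readable difference in this assay, so among these three compounds only the cyclohexyl compound, compound 2, stands apart. Nothing measured here gives a reason for the cyclohexyl group's standing apart.

As far as these compounds go, what stays open is whether the lower number of compound 2 goes with the six-membered ring itself or simply with the count of carbons, which a straight hexyl chain, a cyclopentyl group or a phenyl group on this nitrogen would help to separate. Also open is how a carboxylic acid or an amine at the end of the chain on this nitrogen would read, since the methoxycarbonyl is the only such end group among the compounds shown.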